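Inverted Ring Configuration and the Expected Inhibition of Compound 3

This account rests on a few compounds, and the source may have more. Where it says the series, first, only, none or still open, it means among the compounds named here.

compound 1 `O=C(O)[C@@H]1NCC=C[C@@H]1O`: 14%
compound 2 `O=C(O)[C@H]1NC[C@H](O)[C@H](O)[C@H]1O`: 7.6%

In an assay on isolated protein for inhibition of cytosolic endo-beta-N-acetylglucosaminidase (Homo sapiens), tested at 1000 uM (on this read-out higher numbers stand for more inhibition at the one concentration tested (going by the name of the read-out) and lower numbers for less inhibition), compound 1 gives 14% and compound 2 gives 7.6%. Compound 2 has the lower of the two numbers, but its nearest neighbour, compound 1, lies within the scatter of it, so no order between them can be read. Compound 3 `O=C(O)[C@H]1NC[C@@H](O)[C@@H](O)[C@@H]1O` differs from compound 2 as follows: the two compounds have the same atoms and bonds and differ only in configuration as drawn: 3 of 4 stereo elements differ; a stereocentre at a saturated ring carbon is drawn S in compound 2 and R in compound 3; a stereocentre at a saturated ring carbon is drawn S in compound 2 and R in compound 3; a stereocentre at a saturated ring carbon is drawn S in compound 2 and R in compound 3. Among the compounds with values here, no step between measured compounds is known, so the size of this change has no anchor. Both measured numbers are small and close, and the step of a number 2.4 percentage points higher from compound 2 to compound 3 (within the scatter) is expected to stay within the scatter. Compound 3 is estimated at 10%, in the range 0% to 30%.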

Compound 3, a percentage reported as inhibition, at one concentration (the size of the read-out at that concentration, not a potency): 28%
The estimate for compound 3 lay 18 percentage points below the measured number; the measured number falls inside the stated range.
By their numbers in this assay, from the lowest: compounds 2 and 1 (each within the scatter of the next); then compound 3.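

Compounds 1 and 2 allowed no order in this assay, whereas inverting three saturated ring stereocentres from S to R gives a step beyond the scatter, a number 20.4 percentage points higher from compound 2 to compound 3 (beyond the scatter). This step can be put down to configuration alone, because nothing else changes, as shown by this: the fact that compounds 2 and 3 differ only in the configuration as drawn

As far as these compounds go, the three stereocentres changed together, so it remains open whether one of them or their combination carries the step. Also open, from the compounds shown here alone, is how this configuration would read with a methyl ester or an amide in place of the carboxylic acid.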